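This account rests on a few compounds, and the source may have more. Where it says the series, first, only, none or still open, it means among the compounds named here.

Measured so far in a functional assay on L1210 cells (Mus musculus), with a stated time of 1 days; on this read-out higher numbers stand for higher potency (the scale is a negative logarithm) and lower numbers for lower potency:

- compound 1, `CC1=C(N2CC2)C(=O)C(CC(C)OC(N)=O)=C(N2CC2)C1=O`: 5.86
- compound 2, `CC1=C(N2CC2)C(=O)C(CCC(=O)N(C)C)=C(N2CC2)C1=O`: 5.09
- compound 3, `CC1=C(N2CC2)C(=O)C(COc2ccccc2)=C(N2CC2)C1=O`: 4.68

Compound 2 stands second highest of the three, with compound 3 nearer (a number 0.41 log units lower from compound 2 to compound 3 (beyond the scatter)) and compound 1 further (a number 0.77 log units lower from compound 1 to compound 2 (beyond the scatter), read backwards).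

Compound 4, `COC(CO)C1=C(N2CC2)C(=O)C(C)=C(N2CC2)C1=O`, is not yet measured. Relative to compound 2 the change is 2-hydroxy-1-methoxyethyl in place of 2-(dimethylcarbamoyl)ethyl on a double-bonded ring carbon. Within the data shown here, no measured step matches this change at the same position; the nearest is the step from compound 1 to compound 2, a number 0.77 log units lower from compound 1 to compound 2 (beyond the scatter), where a side chain carrying a hydrogen-bond donor gave the higher number. That suggests a modest rise. The estimate for compound 4 is 5.5, range 5 to 6, a step of a number 0.41 log units higher from compound 2 to compound 4 (beyond the scatter).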

Compound 4, logarithm of the reciprocal of the active concentration, log(1/C): 6.05
Estimate against measurement, compound 4: 0.55 log units below; the whole stated range lies below it.
By their numbers in this assay, from the lowest: compound 3; then compound 2; then compounds 1 and 4 (each within the scatter of the next).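

In this assay, 2-hydroxy-1-methoxyethyl in place of 2-(dimethylcarbamoyl)ethyl gives a number 0.96 log units higher from compound 2 to compound 4 (beyond the scatter) on the double-bonded ring carbon, so a chain carrying a hydroxyl suffices here. The side chain of compound 1 and 2-hydroxy-1-methoxyethyl cannot be separated, with a number 0.19 log units higher from compound 1 to compound 4 (within the scatter) in this series. Nothing available accounts for the rise from compound 2. Going by these compounds, what the hydroxyl and the methoxy each contribute stays open, as does the effect of a primary amine or a carboxylic acid at the chain end.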